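This account rests on a few compounds, and the source may have more. Where it says the series, first, only, none or still open, it means among the compounds named here.

Measured so far:
compound 1, `O=C(Nc1cccc(-c2cccc(F)c2)c1)C(Cl)Cl`, 9530 nM
compound 2, `COc1ccccc1-c1cc(NC(=O)C(Cl)Cl)cc(-c2ccccc2OC)c1`, 25500 nM
compound 3, `CC(C)Oc1ccc(-c2cc(NC(=O)C(Cl)Cl)cc(-c3ccc(OC(C)C)cc3)c2)cc1`, 3820 nM

In a functional assay on A549 cells (Homo sapiens) for cytotoxicity, read by MTT assay, with a stated time of 68 h (on this read-out higher numbers stand for weaker inhibition and lower numbers for stronger inhibition), compound 1 gives 9530 nM, the second highest of the three numbers. Its nearest neighbour is compound 3, which in this assay gives 3820 nM, a lower number beyond the scatter. Furthest from it is compound 2, which gives 25500 nM, a higher number, also beyond the scatter. Going by the values given here, compound 3 carries two isopropoxy-bearing rings and compound 2 two methoxy-bearing rings, so neither is a single-change partner of compound 1, and no direct step is available among the measured compounds.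

The next compound to be tested is compound 4, `COc1cccc(-c2cccc(NC(=O)C(Cl)Cl)c2)c1`. It differs from compound 1 in one place: methoxy in place of fluoro on an aromatic carbon. Among the compounds with values here, no measured pair shows what this change does on its own, and the two substituted partners point in opposite directions.

With nothing to pull the estimate either way, compound 4 is expected to stay close to compound 1, with a step of a 1.1-fold lower number from compound 1 to compound 4 (0.02 log units; within the scatter) that lies within the scatter. Compound 4 is estimated at 9000 nM, with a range from 3500 nM to 25000 nM.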

Compound 4, half-maximal inhibitory concentration: 4310 nM
For compound 4 the middle estimate is 2.1-fold (0.32 log units) above the measured one; measured number inside the range.
By their numbers in this assay, from the lowest: compounds 3 and 4 (each within the scatter of the next); then compound 1; then compound 2.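

In this assay, going by these compounds alone, the exchange of fluoro for methoxy on an aromatic carbon, meta to a large group, gives a 2.2-fold lower number from compound 1 to compound 4 (0.34 log units; beyond the scatter) and so provides the first direct reading of a single change in this set. Within the data shown here, the step is modest, but it lies beyond the scatter, so the number responds to the group at this position, which the earlier compounds could not show because none of them was a single-change partner of another. Nothing among the data given accounts for the step, and the direction of the change stands here as an observation only.

What the compounds shown leave open is whether the lower number belongs to methoxy itself or would also appear with another group at this position, such as a hydroxyl, an amine, an ethoxy or a longer alkoxy chain, and a single step cannot settle this. On these data alone, compound 2 and compound 3 differ from compound 4 in more than one place, so it also remains open whether this step carries over to compounds with two substituted rings.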